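Combining the Acrylamide Linker with the Thiopyridyl Arm

The compounds below may be only part of what the source reports. "The series", "measured", "known", "first", "only" and "open" are said of these compounds alone.

Compound 1 `Nc1ccccc1NC(=O)/C=C/c1ccc(CSc2ccc(Cl)cc2)cc1` in a functional assay on SMMC-7721 cells (Homo sapiens) for inhibition, read by CCK-8 assay, with a stated time of 72 h, tested at 2 uM (on this read-out lower numbers stand for less inhibition of growth and higher numbers for more inhibition of growth at the one concentration tested), gives 15.2%, and compound 2 `Nc1ccccc1NC(=O)c1ccc(CSc2ccc(C(F)(F)F)cn2)cc1` gives 12.4%, the two values lying within the scatter of each other. Compound 3 `Nc1ccccc1NC(=O)/C=C/c1ccc(CSc2ccc(C(F)(F)F)cn2)cc1` has not yet been measured; it differs from compound 1 by 5-(trifluoromethyl)pyridin-2-yl in place of 4-chlorophenyl on a sulfur. No step between measured compounds isolates this change, and the data give no reason to expect a shift beyond the scatter. Compound 3 is therefore expected to stay close to compound 1, the estimated step being a number 1.7 percentage points lower from compound 1 to compound 3 (within the scatter). Compound 3 is estimated in this assay at 13.5%, with a range from 3% to 26%.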

Compound 3, percent growth inhibition at one concentration: 12.1%
Compound 3: middle estimate off by 1.4 percentage points, on the high side; the measured number falls inside the stated range.
By their numbers in this assay, from the lowest: compounds 3, 2 and 1 (each within the scatter of the next).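

In this assay, the sulfur-bound arm can now be read on its own: the step is a number 3.1 percentage points lower from compound 1 to compound 3 (within the scatter). The entering 5-(trifluoromethyl)pyridin-2-yl is the larger group and carries a hydrogen-bond acceptor that 4-chlorophenyl lacks, yet the two arms cannot be told apart on this read-out. As far as these compounds go, whether an amine or a carboxylic acid in place of the arm on the sulfur would move the number beyond the scatter stays open. So does whether a longer chain would do so. Nothing in the data explains why the two arms read alike.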